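Swapping an Ethenyl Chain for an Ethynyl Chain

This account rests on a few compounds, and the source may have more. Where it says the series, first, only, none or still open, it means among the compounds named here.

In a functional assay on KETR3 cells (Homo sapiens) for inhibition, read by MTT assay, with a stated time of 120 h (a higher number here means a weaker inhibitor, a lower number a stronger inhibitor), compound 1 `CNC(=O)c1cccc(-c2ccc(NC(=O)Nc3ccc(Cl)c(C(F)(F)F)c3)cc2)c1` gives 39300 nM. Compound 2 `CNC(=O)/C=C(\C)c1ccc(NC(=O)Nc2ccc(Cl)c(C(F)(F)F)c2)cc1` stands at > 50000 nM, which is a limit of the assay and not a number. That limit is shared by the limit of > 50000 nM in this assay, at which 1 of the 2 values shown sits. For the measured compounds named here, the only measured step is an at least 1.2-fold higher number from compound 1 to compound 2 (0.10 log units; that floor lies within the scatter), and it is the sole guide here.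

Compound 3 `CNC(=O)C#Cc1ccc(NC(=O)Nc2ccc(Cl)c(C(F)(F)F)c2)cc1` differs from compound 2 by 2-(methylcarbamoyl)ethynyl in place of 1-methyl-2-(methylcarbamoyl)ethenyl on an aromatic carbon. Going by the values given here, the one measured step, an at least 1.2-fold higher number from compound 1 to compound 2 (0.10 log units; that floor lies within the scatter), changed the same substituent, yet it gives neither a firm size nor a direction. No step beyond the scatter is therefore expected in this assay, and the assay may again report only a limit. The expected step is an at least 1.2-fold lower number from compound 2 to compound 3 (0.09 log units; that floor lies within the scatter). For compound 3 the estimate is 40000 nM, with an expected range of 15000 nM to 60000 nM.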

Compound 3, half-maximal inhibitory concentration: 24700 nM
For compound 3 the middle estimate is 1.6-fold (0.21 log units) above the measured one; measured number inside the range.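

Compound 3 shows that a chain without a ring, on this aromatic carbon para to a large group, can give a real number in this assay, and the change from the ring-bearing 3-(methylcarbamoyl)phenyl group is a 1.6-fold lower number from compound 1 to compound 3 (0.20 log units; within the scatter). The change from the ethenyl chain is an at least 2.0-fold lower number from compound 2 to compound 3 (0.30 log units; that floor lies within the scatter). Compound 2 stands at a limit and not a number, and because of that this step has only a floor and no exact size: the limit of > 50000 nM in this assay, at which 1 of the 3 values shown sits.

As far as these compounds go, the ethynyl chain and the ethenyl chain differ in both the extra methyl and the type of bond, so the share of each remains open. Also open, from the compounds shown here alone, is how a nitrile, a carboxylic acid or a longer chain would read at the end of the ethynyl chain in place of the methylcarbamoyl group.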